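A few compounds are considered here, and "the series" means these few. Any claim that something is new, unique, unknown or untested is made for them only; others in the source may bear on it.

Measured in an ADME assay on HepG2 2.2.15 cells (Homo sapiens) for cytotoxicity, read by luminescence, with a stated time of 3 days; a lower number here means that less compound is tolerated, a higher number that more compound is tolerated:
- compound 1 `O=C(Nc1ccc(F)c(Cl)c1)c1ccc(F)c(S(=O)(=O)N2C[C@H](O)CC[C@H](O)C2)c1`: 25500 nM
- compound 2 `COC1COCCN(S(=O)(=O)c2cc(C(=O)Nc3ccc(F)c(Cl)c3)ccc2F)C1`: 8700 nM
- compound 3 `O=C(Nc1ccc(F)c(Cl)c1)c1ccc(F)c(S(=O)(=O)N2CCCCCCC2O)c1`: 7000 nM

Compound 3 cannot be told apart from compound 2, with a 1.2-fold lower number from compound 2 to compound 3 (0.09 log units; within the scatter). Both lie under compound 1, with a 3.6-fold lower number from compound 1 to compound 3 (0.56 log units; beyond the scatter) and a 2.9-fold lower number from compound 1 to compound 2 (0.47 log units; beyond the scatter).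

Compound 4 `O=C(Nc1ccc(F)c(Cl)c1)c1ccc(F)c(S(=O)(=O)N2CCCC(O)CC2)c1` brings one change to compound 3, the 4-hydroxyazepan-1-yl group on the sulfonyl sulfur: a group of 8 heavy atoms (6 carbon, 1 nitrogen, 1 oxygen; one seven-membered non-aromatic ring with 1 hetero atom) in place of a group of 9 heavy atoms (7 carbon, 1 nitrogen, 1 oxygen; one eight-membered non-aromatic ring with 1 hetero atom), on a sulfonyl sulfur.

The closest guide is a 3.6-fold lower number from compound 1 to compound 3 (0.56 log units; beyond the scatter), read backwards, since compound 1 also has a seven-membered ring. Compound 2 goes against this, having a seven-membered ring yet the value 8700 nM. Only a small rise in this assay is therefore expected, near the edge of the scatter: a 1.9-fold higher number from compound 3 to compound 4 (0.27 log units; within the scatter). For compound 4 the estimated value is 13000 nM, with an expected range of 6000 nM to 28000 nM.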

Compound 4, half-maximal cytotoxic concentration: 29000 nM
Beside the measured number, compound 4's estimate is 2.2-fold (0.35 log units) below it; measured number outside the range, above it.
By their numbers in this assay, from the lowest: compounds 3 and 2 (each within the scatter of the next); then compounds 1 and 4 (each within the scatter of the next).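

In this assay, the 4-hydroxyazepan-1-yl group is better tolerated than the eight-membered ring (a 4.1-fold higher number from compound 3 to compound 4 (0.62 log units; beyond the scatter)) and than 6-methoxy-1,4-oxazepan-4-yl (a 3.3-fold higher number from compound 2 to compound 4 (0.52 log units; beyond the scatter)). It cannot be told apart from 3,6-dihydroxyazepan-1-yl (a 1.1-fold higher number from compound 1 to compound 4 (0.06 log units; within the scatter)), so the extra hydroxy group of that dihydroxy ring is not needed for a high number. Ring size alone gives no rule, since compound 2 also has a seven-membered ring and goes against the pattern. Nothing available explains these steps. Still open, from the compounds shown here alone, is how a plain azepan-1-yl group or a 4-aminoazepan-1-yl group would stand.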